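A sulfonyl aryl swap from an inactive hydrazide

This account rests on a few compounds, and the source may have more. Where it says the series, first, only, none or still open, it means among the compounds named here.

Compound 1, `CC(=O)Nc1ccc(S(=O)(=O)NNC(=O)c2cccnc2Nc2ccc(Cl)cc2)cc1`, is one of two hydrazides examined in a functional assay on T47D cells (Homo sapiens) for antiproliferative activity; a lower number here means a stronger inhibitor of growth, a higher number a weaker inhibitor of growth. In this assay compound 1 returns > 100000 nM, which is a limit of the assay rather than a number. Its companion compound 2, `O=C(NNS(=O)(=O)c1ccc(F)cc1)c1cccnc1Nc1ccc(Cl)cc1Cl`, in this assay gives > 97700 nM, again a limit and not a number. Compound 1 therefore stands at the top end of what the assay can report, as stated in the limit of > 100000 nM in this assay, at which 1 of the 2 values shown sits, and compound 2 rests at a similar ceiling, as stated in the limit of > 97700 nM in this assay, at which 1 of the 2 values shown sits. Within the data shown here, no pair among the measured compounds differs in only one place, so no measured step is available.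

Compound 3, `O=C(NNS(=O)(=O)c1ccc(Cl)cc1Cl)c1cccnc1Nc1ccc(Cl)cc1`, carries 2,4-dichlorophenyl in place of 4-acetamidophenyl on a sulfonyl sulfur. Since the starting point is a limit, only a move toward stronger inhibition could be registered; a move the other way would stay hidden. Compound 3 is expected to remain near that ceiling because compound 1 sits at the limit of > 100000 nM in this assay, at which 1 of the 2 values shown sits, so the step from compound 1 to compound 3 is estimated as a number no higher from compound 1 to compound 3 (the limit leaves the size open), with compound 3 expected at 100000 nM, within 20000 nM to 300000 nM.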

Compound 3, concentration for total growth inhibition: 51300 nM
For compound 3 the middle estimate is 1.9-fold (0.29 log units) above the measured one, within the range that was stated.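

Compound 3 is the only one of the three hydrazides shown that returns a number rather than a limit in this assay, so a change on the sulfonyl sulfur can bring this series within the range the assay reports. Placing 2,4-dichlorophenyl in place of 4-acetamidophenyl at that position gives an at least 1.9-fold lower number from compound 1 to compound 3 (0.28 log units; that floor lies within the scatter), and that figure is a floor on the step, not its measured size. The floor alone does not clear the usual scatter, so a real gain in growth inhibition is suggested but not established, and the reading for compound 1 remains a limit and not a number: the limit of > 100000 nM in this assay, at which 1 of the 3 values shown sits.

Among these compounds, with only this one swap to read, it remains open whether both chlorine atoms are needed, or whether the 4-acetamidophenyl group simply gives way to any plain aryl ring. From the compounds shown here alone, how a 4-methoxyphenyl ring, a ring bearing an amine or a carboxylic acid, or a longer alkyl chain on the sulfonyl sulfur would read in this assay also stays open, as does the true size of the step from compound 1.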